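Working notes: trifluorophenyl replacement at the ring nitrogen

The source may hold more compounds than are shown below. What is called first, only, known or untested is meant among the compounds shown, and "the series" means these compounds.

Measured so far:
compound 1 `COc1ccc(N2CCN(Cc3csc(N)c3C(=O)c3ccc(Cl)cc3)CC2)cc1` gives -1.2% in a functional assay on CHO cells with adenosine receptor A1 (Homo sapiens) as the target, read by cAMP accumulation and immunoassay, with a stated time of 6 min, tested at 0.01 uM; a higher number here means a weaker effect of the compound at the concentration tested, a lower number a stronger effect
compound 2 `Nc1scc(CN2CCN(c3cc(F)ccc3F)CC2)c1C(=O)c1ccc(Cl)cc1` gives 3.1% in this assay

Compound 2 holds the higher of the two numbers recorded, with compound 1 the nearest, the two separated by a number 4.3 percentage points higher from compound 1 to compound 2 (within the scatter), a gap that stays within the scatter. Compound 3 `Nc1scc(CN2CCN(c3c(F)cc(F)cc3F)CC2)c1C(=O)c1ccc(Cl)cc1` has not yet been measured in this assay. It differs from compound 2 in one place: 2,4,6-trifluorophenyl in place of 2,5-difluorophenyl on an amine nitrogen in a ring. Among the measured compounds shown here, the only step recorded so far, a number 4.3 percentage points higher from compound 1 to compound 2 (within the scatter), also exchanges the group on that same ring nitrogen and lies within the scatter; no measured step exchanges a 2,5-difluorophenyl for a 2,4,6-trifluorophenyl, so the bearing is only indirect. On this basis no step beyond the scatter is expected, the estimated step being a number 1.1 percentage points lower from compound 2 to compound 3 (within the scatter). Compound 3 is therefore expected to give about 2% in this assay, in a range from -8% to 12%.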

Compound 3, a percentage reported as activity, at one concentration (the size of the read-out at that concentration, not a potency): 4.2%
For compound 3 the middle estimate is 2.2 percentage points below the measured one; the range from low to high includes it.
By their numbers in this assay, from the lowest: compounds 1, 2 and 3 (each within the scatter of the next).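

In this assay the exchange of 2,5-difluorophenyl for 2,4,6-trifluorophenyl on the amine nitrogen in the ring gives a number 1.1 percentage points higher from compound 2 to compound 3 (within the scatter), and the exchange of 4-methoxyphenyl for the same group gives a number 5.4 percentage points higher from compound 1 to compound 3 (within the scatter). The three aryl groups now on this ring nitrogen all lie within the scatter of one another, so this change of fluorine pattern, like the earlier exchange, produces no readable difference at the single concentration tested. Nothing available bears on why the read-out stays flat at this position.

As far as these compounds go, whether a group of another kind on this nitrogen, such as a carboxylic acid, an amine or a longer alkyl chain, would move the read-out beyond the scatter stays open. Also open, from the compounds shown here alone, is whether these three compounds would separate at other concentrations, since one concentration gives no potency.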